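Replacing a Methyl with a Methoxy on the Shared Core

The source may report more compounds than this note shows. Statements on the series, on what has been measured and on what is new or still open speak of the compounds shown alone.

Of the compounds shown here, two with a shared core have been measured so far. Compound 1, with the structure `CCCC[C@]1(CC)CS(=O)(=O)c2ccc(C)cc2[C@@H](c2ccc(F)cc2)[C@H]1O`, and compound 2, with the structure `CCCCC1(CCCC)CS(=O)(=O)c2ccc(C)cc2[C@@H](c2ccc(F)cc2)[C@H]1O`, were tested in an assay on cells for inhibition of ileal sodium/bile acid cotransporter (Homo sapiens); on this read-out higher numbers stand for weaker inhibition and lower numbers for stronger inhibition. In this assay compound 1 gives 21 nM, and compound 2 gives 46 nM. Compound 2 thus holds the highest number of the two, and the gap to compound 1 lies beyond the usual scatter, so compound 2 is the weaker inhibitor of the pair.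

Compound 3, with the structure `CCCCC1(CCCC)CS(=O)(=O)c2ccc(OC)cc2[C@@H](c2ccc(F)cc2)[C@H]1O`, has not been measured. It differs from compound 2 in one place: methoxy in place of methyl on an aromatic carbon. Among the compounds with values here, no measured pair shows how this particular exchange moves the numbers, so there is nothing in the present data to set a direction for it. Compound 3 is therefore expected to stay near compound 2, with a step of a 1.2-fold lower number from compound 2 to compound 3 (0.06 log units; within the scatter) that does not clearly leave the scatter. For compound 3 the estimate is 40 nM, with a range from 15 nM to 120 nM.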

Compound 3, half-maximal inhibitory concentration: 50 nM
For compound 3 the middle estimate is 1.3-fold (0.10 log units) below the measured one, within the range that was stated.
By their numbers in this assay, from the lowest: compound 1; then compounds 2 and 3 (each within the scatter of the next).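

In this assay, exchanging methyl for methoxy on this aromatic carbon gives a 1.1-fold higher number from compound 2 to compound 3 (0.04 log units; within the scatter), so the two compounds cannot be told apart on this read-out. Within the data shown here, this is the first look at the position, and it shows that the aromatic carbon can carry methoxy, with 2 heavy atoms and 1 hydrogen-bond acceptor, in place of methyl, with 1 heavy atom and 0 hydrogen-bond acceptors, with no shift in inhibition beyond the usual scatter. No other measurement bears on this result, so the data offer no explanation for it.

Methyl and methoxy are the only two groups seen at this position, so the compounds shown leave open how an amine, a carboxylic acid or a longer chain such as ethoxy would read there. On these data alone, this single pair also rests on the core of compound 2, and it remains open whether the same exchange would behave in the same way on the core of compound 1.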